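Swapping the Side Chain at a Saturated Ring Carbon

The compounds below may be only part of what the source reports. "The series", "measured", "known", "first", "only" and "open" are said of these compounds alone.

Of the compounds shown here, three have been measured in a functional assay on HEK293 cells for agonist activity at G-protein coupled receptor 39 (Homo sapiens), read by scintillation proximity assay and inositol phosphate accumulation, with a stated time of 75 min; on this read-out lower numbers stand for an effect already at smaller amounts and higher numbers for an effect only at larger amounts of compound. Compound 1 `Cc1nn(-c2ncnc3nc[nH]c23)c2c1C(C(=O)NCc1ccccc1)CC(=O)N2` gives 2930 nM. Compound 2 `Cc1cc(C)nc(-n2nc(C)c3c2NC(=O)CC3c2ccc(COc3cccc(Cl)c3)cc2)n1`, built on a different core, gives 3000 nM; the two numbers lie within the scatter of each other, so no order between them can be claimed. Compound 3 `Cc1nn(-c2ncnc3nc[nH]c23)c2c1C(NC(=O)Cc1cccs1)CC(=O)N2` gives 244 nM. Among the three numbers, compound 1 stands second highest, nearest to compound 2 and furthest from compound 3, with a 12-fold lower number from compound 1 to compound 3 (1.08 log units; beyond the scatter).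

Compound 4 `Cc1nn(-c2ncnc3nc[nH]c23)c2c1C(OC(=O)c1ccc(F)cc1)CC(=O)N2` has not yet been measured. It shares the core of compound 1 and differs from it in one place: ((4-fluorophenyl)carbonyl)oxy in place of benzylcarbamoyl on a saturated ring carbon. Within the data shown here, the only measured step at the same saturated ring carbon, a 12-fold lower number from compound 1 to compound 3 (1.08 log units; beyond the scatter), shows that exchanging the group at this position can move the number a long way, in that case toward a lower value. The group entering in compound 4 closely matches neither the group that left nor the group that entered in compound 3, so the direction of the change is uncertain; a sizeable shift is possible, but a small one cannot be ruled out. Taking that one measured step as a rough guide, compound 4 is expected to give 1200 nM, a step of a 2.4-fold lower number from compound 1 to compound 4 (0.39 log units; beyond the scatter), with a range from 250 nM to 6000 nM.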

Compound 4, half-maximal effective concentration: 245 nM
Compound 4: the middle estimate sits 4.9-fold (0.69 log units) above what was measured; measured number outside the range, below it.
By their numbers in this assay, from the lowest: compounds 3 and 4 (each within the scatter of the next); then compounds 1 and 2 (each within the scatter of the next).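

Replacing benzylcarbamoyl with ((4-fluorophenyl)carbonyl)oxy on the saturated ring carbon gives a 12-fold lower number from compound 1 to compound 4 (1.08 log units; beyond the scatter), so the large step seen earlier is no longer tied to a single replacement group. The two replacement groups cannot be told apart here, with a 1.0-fold higher number from compound 3 to compound 4 (0.00 log units; within the scatter), and since ((4-fluorophenyl)carbonyl)oxy has no hydrogen-bond donor, a group at this carbon does not need one to reach this level. In compound 3 and compound 4 the group is joined to the ring carbon through a nitrogen or an oxygen, whereas in compound 1 it is joined through a carbonyl carbon, but no measurement here explains why the numbers differ.

On these data alone, it remains open whether a plain benzoyloxy group, without the fluorine, would give a similar number, and whether the link atom or the aromatic ring matters more. A small group such as a hydroxyl or a free amine on the same carbon would show whether any of this larger side chain is needed at all.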